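Adding a methyl to the diol side chain of compound 2

This account rests on a few compounds, and the source may have more. Where it says the series, first, only, none or still open, it means among the compounds named here.

Measured in a functional assay on cells (T-cell, Homo sapiens) for inhibition, read by scintillation counting and thymidine incorporation, with stated times of 60 min and 3 days; a higher number here means a weaker inhibitor, a lower number a stronger inhibitor:
- compound 1 `COc1ccc(-c2cc3c(N[C@H](CO)CC4CC4)c(C(N)=O)cnn3c2)cn1`: 290 nM
- compound 2 `COc1ccc(-c2cc3c(NC(CO)CO)c(C(N)=O)cnn3c2)cn1`: 11000 nM

Compound 2 holds the higher of the two numbers, at 11000 nM, which makes it the weaker inhibitor of the pair. Compound 3 `COc1ccc(-c2cc3c(N[C@H](CO)[C@@H](C)O)c(C(N)=O)cnn3c2)cn1` differs from compound 2 by a single change: methyl in place of hydrogen on a saturated chain carbon bound to an oxygen on a saturated carbon and a saturated chain carbon. Cut one bond further out, 2-hydroxy-1-(hydroxymethyl)ethyl becomes 2-hydroxy-1-(hydroxymethyl)propyl.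

Among the compounds with values here, one measured step bears on this, and only indirectly. It changes the group on the same nitrogen: a 38-fold higher number from compound 1 to compound 2 (1.58 log units; beyond the scatter). Within the data shown here, the step is large, so the number responds strongly to this group, but no measured pair adds a methyl at this place. The change to compound 3 is much smaller than that exchange, so a modest step in this assay is expected. A lower number is tentatively expected, resting only on compound 1 at 290 nM, which carries the larger 1-(cyclopropylmethyl)-2-hydroxyethyl group. The step could still fall within the scatter.

The estimate for compound 3 is 5000 nM, with an expected range of 1500 nM to 15000 nM. The estimated step reads a 2.2-fold lower number from compound 2 to compound 3 (0.34 log units; beyond the scatter).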

Compound 3, half-maximal inhibitory concentration: 370 nM
For compound 3 the middle estimate is 14-fold (1.13 log units) above the measured one; measured number below the stated range.
By their numbers in this assay, from the lowest: compounds 1 and 3 (each within the scatter of the next); then compound 2.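

In this assay, a single methyl on the saturated chain carbon bound to an oxygen gives a 30-fold lower number from compound 2 to compound 3 (1.47 log units; beyond the scatter), a large step that shows this position responds strongly to one added carbon, which the earlier exchange of whole groups could not isolate. The exchange of cyclopropylmethyl for 1-hydroxyethyl reads a 1.3-fold higher number from compound 1 to compound 3 (0.11 log units; within the scatter), which lies within the scatter, so the cyclopropylmethyl group is not required for a number in this range, and a side chain with two hydroxyl groups can match it once the methyl is present. No supporting data are available to account for the size of the methyl step.

Compound 3 carries a defined configuration at both substituted chain carbons, so these compounds do not separate the contribution of the methyl from that of the configuration shown. They also leave open whether an ethyl or a longer chain in place of that methyl would lower the number further, and whether an amine in place of the neighbouring hydroxyl would keep the effect.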